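Series notes: bromo for fluoro on the phenoxy arm

The compounds below may be only part of what the source reports. "The series", "measured", "known", "first", "only" and "open" are said of these compounds alone.

Measured so far:
compound 1 `COc1cc2c(cc1CC=C(C)C)/C(=N/NC(N)=O)C[C@@H](c1ccc(O)cc1)O2`: 67%
compound 2 `COc1cc2c(cc1CC=C(C)C)C(=O)C[C@@H](c1ccc(Oc3ccc(F)cc3)cc1)O2`: 19%
compound 3 `COc1ccc([C@@H]2C/C(=N/OCc3cn(-c4cccc(CO)c4)nn3)c3cc(CC=C(C)C)c(OC)cc3O2)cc1`: 34%

In a functional assay on PC-3 cells (Homo sapiens) for inhibition, read by sulforhodamine B assay, with a stated time of 48 h, tested at 50 uM (on this read-out higher numbers stand for more inhibition of growth at the one concentration tested and lower numbers for less inhibition of growth), compound 1 gives 67%, compound 3 gives 34% and compound 2 gives 19%, the lowest of the three; its gaps to compound 3 and to compound 1 both lie beyond the scatter. Within the data shown here, no two measured compounds differ in one place, so no single step has been sized from the numbers in hand. Compound 4 `COc1cc2c(cc1CC=C(C)C)C(=O)C[C@@H](c1ccc(Oc3ccc(Br)cc3)cc1)O2` differs from compound 2 only by bromo in place of fluoro on an aromatic carbon, 4-fluorophenoxy to 4-bromophenoxy. Nothing in the series sizes such a change, so in this assay a step within the scatter, leaning slightly upward, is expected. The step expected is a number 6 percentage points higher from compound 2 to compound 4 (within the scatter). Compound 4 is therefore estimated at 25%, within 8% to 45%.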

Compound 4, percent growth inhibition at one concentration: 55%
The estimate for compound 4 lay 30 percentage points below the measured number; the whole stated range lies below it.
By their numbers in this assay, from the lowest: compound 2; then compound 3; then compound 4; then compound 1.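

In this assay, among these compounds, the halogen on the phenoxy arm proves to be a sensitive place: bromo in place of fluoro gives a number 36 percentage points higher from compound 2 to compound 4 (beyond the scatter) and so sizes a single-atom change for the first time. The exchange sits on an aromatic carbon, para to a large group, and leaves the rest of the structure unchanged. No measurement at hand explains the size of this step.

Whether the gain is particular to bromo remains open, with chloro, iodo, methyl and the unsubstituted phenoxy absent from the compounds shown. Also open, going by these compounds, is whether the same exchange would hold if the carbonyl of compound 2 were replaced.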